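The compounds below may be only part of what the source reports. "The series", "measured", "known", "first", "only" and "open" are said of these compounds alone.

In a functional assay on Caco-2 cells (Homo sapiens) for antiproliferative activity, with a stated time of 48 h (a lower number here means a stronger inhibitor, a higher number a weaker inhibitor), compound 1 `CCN(CC)c1ccc(-c2ccc(C(=O)OC)cc2)nn1` gives 250 nM. Compound 2 `CCOC(=O)c1ccc(-c2ccc(N(CC)CC)nn2)cc1` differs from compound 1 by methyl in place of hydrogen on a saturated chain carbon bound to an oxygen next to a carbonyl group, and in this assay compound 2 gives 4000 nM. That single change brought a 16-fold higher number from compound 1 to compound 2 (1.20 log units; beyond the scatter). Compound 3 `CCOC(=O)c1ccc(-c2ccc(OCC)nn2)cc1` carries an ethoxy group where compound 2 carries a diethylamino group, and the step here is an at least 6.2-fold higher number from compound 2 to compound 3 (0.79 log units; beyond the scatter). For compound 3 the result in this assay is only a limit, > 25000 nM, the point at which (the limit of > 25000 nM in this assay, at which 1 of the 3 values shown sits). Compound 4 `CCOC(=O)c1ccc(-c2ccc(OC(C)C)nn2)cc1` has not yet been measured. It differs from compound 3 by methyl in place of hydrogen on a saturated chain carbon bound to an oxygen on an aromatic ring and a saturated chain carbon. For the measured compounds named here, this is the same kind of change as the one from compound 1 to compound 2, not the same change: there the carbon was bound to an oxygen next to a carbonyl group, here it is bound to an oxygen on an aromatic ring and a saturated chain carbon. How the core of compound 1 and the core of compound 3 differ is not broken down here. Beside the earlier step, the step that the limit leaves unreadable from compound 3 to compound 4 is expected, resting on a 16-fold higher number from compound 1 to compound 2 (1.20 log units; beyond the scatter). Compound 3 already sits at a limit in this assay. Compound 4 is therefore estimated at 40000 nM in this assay, most likely again reported only as a limit.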

Compound 4, half-maximal inhibitory concentration: > 25000 nM
Compound 4 ended at the assay's limit (the forecaster's own chance of this, stated with the estimate: 80%); the middle value does not contradict the limit.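

In this assay compound 4 gives > 25000 nM, which is a limit of the assay and not a number; compound 3 also stands at a limit, so the step between them cannot be read. The added methyl that came with a 16-fold higher number from compound 1 to compound 2 (1.20 log units; beyond the scatter) on the core of compound 1 is therefore neither confirmed nor ruled out as a guide to the change from ethoxy to isopropoxy on the core of compound 3. What can be read is an at least 6.2-fold higher number from compound 2 to compound 4 (0.79 log units; beyond the scatter), with isopropoxy in place of diethylamino, and the size of that step is set by the limit: the limit of > 25000 nM in this assay, at which 2 of the 4 values shown sit.

The compounds shown leave open whether another amine on the same aromatic carbon, such as dimethylamino, would give a value that can be read in this assay. They also leave open what a carboxylic acid in place of the ester would do, and whether ethoxy paired with a methyl ester would come off the limit.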